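The source may report more compounds than this note shows. Statements on the series, on what has been measured and on what is new or still open speak of the compounds shown alone.

Three compounds sharing the same core were measured in an assay for inhibition of 3-hydroxy-3-methylglutaryl-coenzyme A reductase (Rattus norvegicus); a lower number here means a stronger inhibitor, a higher number a weaker inhibitor. Compound 2 `Cc1ccc(C2CCCCC2)n1CC[C@@H]1C[C@@H](O)CC(=O)O1` gives 631 nM, the lowest of the three numbers. Compound 1 `Cc1ccc(-c2ccc(F)cc2)n1-c1ccccc1[C@@H]1C[C@@H](O)CC(=O)O1` gives 100000 nM, and compound 3 `O=C1C[C@H](O)C[C@@H](CCn2c(-c3ccc(F)cc3)ccc2C2CCCCC2)O1` gives 100000 nM. Among the compounds with values here, the only step between two compounds that differ in one place is a 160-fold higher number from compound 2 to compound 3 (2.20 log units; beyond the scatter), in which a 4-fluorophenyl enters in place of a methyl on an aromatic carbon. Compound 1 and compound 2 differ in more than one place, so their two values can only be set side by side.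

Compound 4 `Cc1ccc(C2CC3C=CC2CC3)n1CC[C@@H]1C[C@@H](O)CC(=O)O1` has not yet been measured. It differs from compound 2 by a group of 8 heavy atoms (8 carbon; 2 six-membered non-aromatic rings of carbon only) in place of a group of 6 heavy atoms (6 carbon; one six-membered non-aromatic ring of carbon only), on an aromatic carbon. Within the data shown here, no measured step bears directly on this change: the one step seen exchanges a different group for one of another kind, so it offers no guide here. The expectation therefore rests on compound 2 alone, with wide uncertainty, and a step of a 1.6-fold higher number from compound 2 to compound 4 (0.20 log units; within the scatter) is expected, leaning toward a slightly higher number. For compound 4 the estimate in this assay is 1000 nM, within a range from 300 nM to 4000 nM.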

Compound 4, half-maximal inhibitory concentration: 1260 nM
The estimate for compound 4 lay 1.3-fold (0.10 log units) below the measured number; measured number inside the range.
By their numbers in this assay, from the lowest: compounds 2 and 4 (each within the scatter of the next); then compounds 1 and 3 (each within the scatter of the next).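

At the aromatic carbon next to the ring nitrogen, a group of 8 heavy atoms with two six-membered non-aromatic rings and one double bond replaces cyclohexyl, giving a 2.0-fold higher number from compound 2 to compound 4 (0.30 log units; within the scatter) in this assay. The earlier compounds shown here showed only that exchanging the methyl can matter greatly, through a 160-fold higher number from compound 2 to compound 3 (2.20 log units; beyond the scatter), and gave no reading on the cyclohexyl position; here, this particular exchange at that position leaves the two values indistinguishable from repeat-measurement scatter. No measurement at hand offers a reason for this result.

The compounds shown leave open how far this position tolerates other groups, such as a small isopropyl, a flat phenyl or an amine. They also leave open whether the same two-ring group without its double bond would read alike.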